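The compounds below may be only part of what the source reports. "The series", "measured", "known", "first", "only" and "open" are said of these compounds alone.

Compound 3 `CN(C)CCCCCSC1=Nc2ccccc2C(CC(=O)NCc2ccc(F)cc2)N1c1ccc(-c2ccccc2)cc1` stands second highest of the three compounds measured in an assay on cells for inhibition of Voltage-dependent T-type calcium channel subunit alpha-1I (Homo sapiens), read by patch clamp, tested at 10 uM; on this read-out lower numbers stand for less inhibition and higher numbers for more inhibition at the one concentration tested (going by the name of the read-out); in this assay compound 3 gives 69.3%. Its nearest neighbour is compound 1 `CN(C)CCCCCSC1=Nc2ccccc2C(CC(=O)NCc2ccccc2)N1c1ccc(-c2ccccc2)cc1`, which in this assay gives 85.6%; the furthest is compound 2 `O=C(CC1c2ccccc2N=C(SCCCCCN2CCCC2)N1c1ccccc1)NCc1ccc(F)cc1`, which in this assay gives 22.1%. Within the data shown here, the only measured single-place step, a number 16.3 percentage points lower from compound 1 to compound 3 (beyond the scatter), concerns a fluoro in place of hydrogen on an aromatic carbon and does not touch the change now followed. Compound 4 `CN(C)CCCCCSC1=Nc2ccccc2C(CC(=O)NCc2ccc(F)cc2)N1c1ccccc1` differs from compound 3 in one place: hydrogen in place of phenyl on an aromatic carbon, the same difference read one bond further out as 4-phenylphenyl to phenyl. Among the measured compounds shown here, no measured pair isolates this change. For the measured compounds named here, compound 2 carries a phenyl at that place yet differs from compound 3 in a second place as well, so the two values show only that the compound bearing the phenyl gives the lower number. A step of a number 31.3 percentage points lower from compound 3 to compound 4 (beyond the scatter) in this assay is therefore expected, downward but uncertain in size. Compound 4 is estimated at 38%, with a range from 15% to 62%.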

Compound 4, a percentage reported as inhibition, at one concentration (the size of the read-out at that concentration, not a potency): "not active" (no number reported)
For compound 4 the study gives words and no number, and the estimate cannot be compared.
By their numbers in this assay, from the lowest: compound 2; then compound 3; then compound 1.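

Among these compounds, compound 4 is reported in this assay only in words, as "not active", so no step from compound 3 to compound 4 can be read. How large the change from 4-phenylphenyl to phenyl is stays open, and nothing shown offers an explanation.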